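A Triazolylmethyl Group Enters at the Aromatic Nitrogen

The source may hold more compounds than are shown below. What is called first, only, known or untested is meant among the compounds shown, and "the series" means these compounds.

Three compounds sharing one core were tested in a functional assay on A-375 cells (Homo sapiens) for cytotoxicity, read by MTT assay, with a stated time of 72 h; on this read-out lower numbers stand for stronger inhibition and higher numbers for weaker inhibition. Compound 2 `O=C1c2c[n+]([O-])c3ccccc3c2C(=O)c2[nH]c3ccccc3c21` carries only a hydrogen on the aromatic nitrogen of its core and gives 660 nM, the lowest number of the three. Compound 1 `CN1CCN(CCCCCn2c3c(c4ccccc42)C(=O)c2c[n+]([O-])c4ccccc4c2C3=O)CC1` bears a long chain on that nitrogen and gives 1710 nM, while compound 3 `CCCN1CCN(CCCCn2c3c(c4ccccc42)C(=O)c2c[n+]([O-])c4ccccc4c2C3=O)CC1`, with a related chain, gives 870 nM. The comparison a 2.6-fold lower number from compound 1 to compound 2 (0.41 log units; beyond the scatter) shows that removing such a chain lowered the number, and the step of a 2.0-fold lower number from compound 1 to compound 3 (0.29 log units; within the scatter) shows that reshaping the chain itself moved the number little. Compound 4 `O=C1c2c[n+]([O-])c3ccccc3c2C(=O)c2c1c1ccccc1n2Cc1cn(C[C@H](O)CO)nn1` is compound 2 with a new group: (1-(2,3-dihydroxypropyl)-1H-1,2,3-triazol-4-yl)methyl in place of hydrogen on an aromatic nitrogen. For the measured compounds named here, only the step from compound 1 to compound 2 bears directly on this change, since it too concerns a group entering or leaving that nitrogen, and its size was modest. A group of a different kind enters here, so the direction is uncertain, but a modest rise in the number is expected, a 1.8-fold higher number from compound 2 to compound 4 (0.26 log units; within the scatter). The estimate for compound 4 is 1200 nM, with a range from 500 nM to 3000 nM.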

Compound 4, half-maximal inhibitory concentration: 350 nM
Compound 4: the middle estimate sits 3.4-fold (0.54 log units) above what was measured; measured number outside the range, below it.
By their numbers in this assay, from the lowest: compounds 4, 2, 3 and 1 (each within the scatter of the next, the first and the last beyond it).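

For the compounds shown here, until this result, the only group on this aromatic nitrogen with a step from hydrogen beyond the scatter was the chain of compound 1, which left open whether any large group here would raise the number. In this assay, a 1.9-fold lower number from compound 2 to compound 4 (0.28 log units; within the scatter) shows that (1-(2,3-dihydroxypropyl)-1H-1,2,3-triazol-4-yl)methyl, with its 11 heavy atoms, can sit at this position without a shift that stands clear of the scatter, while a 2.5-fold lower number from compound 3 to compound 4 (0.40 log units; beyond the scatter) and a 4.9-fold lower number from compound 1 to compound 4 (0.69 log units; beyond the scatter) show that the identity of the group on this nitrogen matters, not merely its presence. Nothing available explains why these groups differ.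

The compounds shown do not separate the triazole ring from the 2,3-dihydroxypropyl group on it, a question that a triazolylmethyl group bearing a plain propyl chain or a carboxylic acid could address. From the compounds shown here alone, how the opposite arrangement at the stereocentre would read also remains open.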